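Dropping the Alkyne Arm from a Fused Core

The source may hold more compounds than are shown below. What is called first, only, known or untested is meant among the compounds shown, and "the series" means these compounds.

Compound 1 `O=c1nc2oc(CCCCl)c(C#CCCCCl)c2cn1Cc1cn(-c2ccc(Cl)cc2)nn1` — > 100000 nM
Compound 2 `CCCCCc1ccc(C#Cc2c(-c3ccc(CCCCC)cc3)oc3nc(=O)n(Cc4cn(-c5ccc(Cl)cc5)nn4)cc23)cc1` — > 100000 nM
Compound 3 `O=c1nc2oc(C3CC3)c(C#CC3CC3)c2cn1Cc1cn(-c2ccccc2F)nn1` — 49100 nM

Of the compounds shown here, three have been measured in a functional assay on SW-620 cells (Homo sapiens) for antiproliferative activity, read by MTT assay, with a stated time of 72 h; on this read-out lower numbers stand for stronger inhibition and higher numbers for weaker inhibition. For compound 1 the value > 100000 nM is a limit of the assay, not a number. For compound 2 the value > 100000 nM is likewise a limit. Compound 3 gives 49100 nM, a measured number and the only one in the set. For the measured compounds named here, compound 1 therefore stands at the limit of > 100000 nM in this assay, at which 2 of the 3 values shown sit, so nothing places it above or below compound 2, and compound 3 is the only compound with a number to compare against.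

Compound 4 `O=c1nc2oc(CCCCl)cc2cn1Cc1cn(-c2ccc(Cl)cc2)nn1` differs from compound 1 by hydrogen in place of 5-chloropent-1-yn-1-yl on an aromatic carbon. Going by the values given here, no pair of measured compounds differs in a single place, so no measured step guides the size of this change. Compound 1 offers only a limit, so the most that can be expected for compound 4 is that it stays near that limit, with no move beyond the usual scatter in either direction. Compound 4 is expected to show 100000 nM, with a range from 30000 nM to 300000 nM. The step of a number no higher from compound 1 to compound 4 (the limit leaves the size open) is thus expected to be essentially flat, and a limit rather than a number is the more likely outcome.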

Compound 4, half-maximal inhibitory concentration: > 100000 nM
Compound 4: only a limit was reported (the forecaster's own chance of this, stated with the estimate: 70%); the middle value sits exactly at the limit.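

In this assay compound 4 gives > 100000 nM, which is a limit and not a number. Compound 1 also stands at a limit, so no step can be read between compound 1 and compound 4. The compounds shown leave open whether hydrogen in place of 5-chloropent-1-yn-1-yl alters antiproliferative activity at all.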